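The compounds below may be only part of what the source reports. "The series", "measured", "known", "first", "only" and "open" are said of these compounds alone.

Measured so far:
compound 1 `CC1CCC(/C=N/c2ccc(F)cc2)=C2NC=C(C(=O)O)C(=O)N21`, 10.6 umol/kg
compound 2 `CC1CCC(/C=N/c2ccccc2O)=C2NC=C(C(=O)O)C(=O)N21`, 4.11 umol/kg

Both numbers come from a functional assay on the whole organism with Rattus norvegicus as the target; on this read-out lower numbers stand for an effect already at smaller amounts and higher numbers for an effect only at larger amounts of compound. Compound 2 gives the lowest of the two; compound 1 is the nearest, and the step of a 2.6-fold lower number from compound 1 to compound 2 (0.41 log units; beyond the scatter) is the only one measured. Compound 3 `CC1CCC(/C=N/c2ccc(O)cc2)=C2NC=C(C(=O)O)C(=O)N21` differs from compound 2 as follows: 4-hydroxyphenyl in place of 2-hydroxyphenyl on a double-bonded nitrogen. Going by the values given here, no measured step compares 2-hydroxyphenyl with 4-hydroxyphenyl on this nitrogen; the step from compound 1 to compound 2 exchanged a different group and bears only loosely on the change. A step within the scatter is therefore expected for compound 3, in either direction: a 1.5-fold higher number from compound 2 to compound 3 (0.16 log units; within the scatter). In this assay compound 3 is estimated at 6 umol/kg, range 2.5 umol/kg to 15 umol/kg.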

Compound 3, dose for 50% inhibition: 1.2 umol/kg
The estimate for compound 3 lay 5.0-fold (0.70 log units) above the measured number; the whole stated range lies above it.
By their numbers in this assay, from the lowest: compound 3; then compound 2; then compound 1.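

In this assay the place of the hydroxy group on the phenyl ring matters: the two groups have the same atoms, yet 4-hydroxyphenyl in place of 2-hydroxyphenyl gives a 3.4-fold lower number from compound 2 to compound 3 (0.53 log units; beyond the scatter). Hydroxy in place of fluoro on an aromatic carbon gives an 8.8-fold lower number from compound 1 to compound 3 (0.95 log units; beyond the scatter), so the identity of the group counts as well as its place. No supporting data bear on the cause of either step.

Still open, going by these compounds, is whether an amine or a methoxy group could stand in for the hydroxy group in 4-hydroxyphenyl and keep the low number of compound 3.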